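This account rests on a few compounds, and the source may have more. Where it says the series, first, only, none or still open, it means among the compounds named here.

In an ADME assay on microsomes from liver (Mus musculus, strain CD-1) for metabolic stability, read by LC-MS, using NADPH, with a stated time of 60 min, tested at 1 uM (a higher number here means that the compound lasts longer, a lower number that the compound disappears faster), compound 1 `CN(C)c1ccc(C2CCCN2Cc2ccc(-c3ccccc3[N+](=O)[O-])o2)cc1` gives 0.0158 h and stands level with compound 2 `COc1ccc(C2CCCN2Cc2ccc(-c3ccccc3[N+](=O)[O-])o2)cc1` at 0.0122 h. Compound 3 `Cc1cc([N+](=O)[O-])ccc1-c1ccc(CN2CCCC2c2ccc(N(C)C)cc2)o1` differs from compound 1 by 2-methyl-4-nitrophenyl in place of 2-nitrophenyl on an aromatic carbon and keeps the rest of the core. Going by the values given here, the one measured step (in which a 1.3-fold lower number from compound 1 to compound 2 (0.11 log units; within the scatter) is the size) concerns a different group, so no measurement yet covers this change, and the half-life of compound 1 at 0.0158 h remains the best anchor. No step beyond the scatter is expected, the estimate being a 1.1-fold lower number from compound 1 to compound 3 (0.02 log units; within the scatter) in this assay. For compound 3 the expected half-life is 0.015 h (estimated range 0.007 h to 0.035 h).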

Compound 3, half-life: 0.0607 h
For compound 3 the middle estimate is 4.0-fold (0.61 log units) below the measured one; the whole stated range lies below it.
By their numbers in this assay, from the lowest: compounds 2 and 1 (each within the scatter of the next); then compound 3.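

Going by these compounds alone, the aryl group on the aromatic carbon next to the ring oxygen is a position where this assay responds: a 3.8-fold higher number from compound 1 to compound 3 (0.58 log units; beyond the scatter), whereas the one earlier step, methoxy in place of dimethylamino, stayed within the scatter. The change from 2-nitrophenyl to 2-methyl-4-nitrophenyl alters the methyl group and the nitro placement together, so the step cannot be divided between them. Nothing available bears on the cause of this step. Open, from the compounds shown here alone, are the separate contributions of methyl and nitro placement, and whether an amine or a carboxylic acid in place of the nitro group would keep this half-life.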